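Does the Fluorine on the Benzyl Group Matter?

The source may report more compounds than this note shows. Statements on the series, on what has been measured and on what is new or still open speak of the compounds shown alone.

Compound 3 `C=C(Br)C(=O)Nc1cccc(/C=C2\SC(=O)N(Cc3ccc(F)cc3)C2=O)c1` carries a 4-fluorobenzyl group on the shared core. In a functional assay on FM3A cells (Mus musculus) for cytotoxicity, read by cell counting, with a stated time of 2 days (a higher number here means a weaker inhibitor, a lower number a stronger inhibitor), compound 3 gives 920 nM, the highest of the two numbers shown, with compound 1 `C=C(Br)C(=O)Nc1cccc(/C=C2\SC(=O)N(Cc3cccc(F)c3)C2=O)c1` nearest at 690 nM. Among the compounds with values here, the only measured step, a 1.3-fold higher number from compound 1 to compound 3 (0.12 log units; within the scatter), lies within the scatter. Compound 2 `Nc1cccc(/C=C2\SC(=O)N(Cc3ccccc3)C2=O)c1` gives only a limit, > 250000 nM (the limit of > 250000 nM in this assay, at which 1 of the 3 values shown sits). Compound 4 `C=C(Br)C(=O)Nc1cccc(/C=C2\SC(=O)N(Cc3ccccc3)C2=O)c1` differs from compound 3 by hydrogen in place of fluoro on an aromatic carbon. Compound 2 and compound 4 differ at another place, and the limit of compound 2 does not speak to the fluorine. Moving the fluorine changed little, and removing it is therefore expected to change little as well. Compound 4 is expected to give 1000 nM (range 400 nM to 2500 nM), an estimated step of a 1.1-fold higher number from compound 3 to compound 4 (0.04 log units; within the scatter) within the scatter.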

Compound 4, half-maximal inhibitory concentration: 810 nM
Compound 4: the middle estimate sits 1.2-fold (0.09 log units) above what was measured, within the range that was stated.
By their numbers in this assay, from the lowest: compounds 1, 4 and 3 (each within the scatter of the next). At a limit, above all of these: compound 2.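

With the fluorine gone altogether, the numbers still do not separate: a 1.1-fold lower number from compound 3 to compound 4 (0.06 log units; within the scatter) and a 1.2-fold higher number from compound 1 to compound 4 (0.07 log units; within the scatter) both lie within the scatter, so in this assay neither the place of the fluorine nor its presence on the benzyl group can be told apart. What does register lies at the other end of the molecule: an at least 300-fold lower number from compound 2 to compound 4 (2.48 log units; beyond the scatter) comes with (1-bromoethenyl)carbonyl in place of hydrogen on the nitrogen on the aromatic ring. The value of compound 2 is a limit, not a number. Still open, as far as these compounds go, is whether methoxy or chloro at the fluorine's place would behave the same, and whether a plain acetyl group on that nitrogen would match compound 4.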